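The source may report more compounds than this note shows. Statements on the series, on what has been measured and on what is new or still open speak of the compounds shown alone.

Compound 1 `COc1ccc(Nc2nc(N)c(C(=O)c3ccc(OC)c(OC)c3)s2)cc1` is the strongest of the three measured compounds: in a functional assay on HeLa cells (Homo sapiens) for antiproliferative activity, read by cell counting, with a stated time of 2 days (a lower number here means a stronger inhibitor, a higher number a weaker inhibitor), compound 1 gives 52 nM. Compound 3 `COc1ccc(Nc2nc(N)c(C(=O)c3cc(OC)c(OC)c(OC)c3)s2)cc1` differs from it only by methoxy in place of hydrogen on an aromatic carbon and gives 560 nM, so the step of an 11-fold higher number from compound 1 to compound 3 (1.03 log units; beyond the scatter) weakened the inhibitor markedly. Compound 2 `COc1ccccc1C(=O)c1sc(Nc2ccccc2)nc1N` gives 1200 nM, the highest number of the set; the difference between the core of compound 2 and that of compound 1 is not broken down here, and only the two values show that compound 1 is the stronger.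

Compound 4 `COc1ccc(Nc2nc(N)c(C(=O)c3ccccc3OC)s2)cc1` differs from compound 2 by methoxy in place of hydrogen on an aromatic carbon. This is the same kind of change as that from compound 1 to compound 3, but at a different place: there the entering group sat ortho to a methoxy group, meta to a large group and meta to a methoxy group, whereas here it sits para to a large group, on the ring that in compound 1 already carries it. Compound 4 is expected to give 350 nM, plausibly between 70 nM and 1500 nM. The expected step of a 3.4-fold lower number from compound 2 to compound 4 (0.54 log units; beyond the scatter) runs opposite to an 11-fold higher number from compound 1 to compound 3 (1.03 log units; beyond the scatter) because compound 1, which carries this methoxy, gives 52 nM.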

Compound 4, half-maximal inhibitory concentration: 17 nM
Compound 4: middle estimate off by 21-fold (1.31 log units), on the high side, and the stated range ends above it.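

In this assay, methoxy in place of hydrogen, para to a large group, gives a 71-fold lower number from compound 2 to compound 4 (1.85 log units; beyond the scatter), so this single small change can have a large effect in this series. Set beside the earlier step, the same kind of change moves the numbers in opposite directions, and the gap between the two steps is itself large: the same change on two cores in this assay, an 11-fold higher number (1.03 log units; beyond the scatter) from compound 1 to compound 3 and a 71-fold lower number (1.85 log units; beyond the scatter) from compound 2 to compound 4, 760-fold (2.88 log units) apart, beyond the scatter of two such steps. A change that carries the same name therefore cannot be assumed to act alike on another core here, but these two steps differ both in where the methoxy enters and in the core that receives it, so they cannot show which of the two matters, and they give no general rule.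

The compounds shown leave open whether an ethoxy, a hydroxyl or an amine in place of this methoxy would give a number like that of compound 4. They also leave open how the step to the 4-methoxyphenyl group would turn out on the core of compound 1 or compound 3.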